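The source may hold more compounds than are shown below. What is called first, only, known or untested is meant among the compounds shown, and "the series" means these compounds.

Of the compounds shown here, three have been measured in an ADME assay on Caco-2 cells (Homo sapiens) for permeability, read by LC-MS, in the apical to basolateral direction, with a stated time of 60 min, at pH 6.5; on this read-out lower numbers stand for lower permeability and higher numbers for higher permeability. Compound 1, `O=C(NCc1cc(Cl)ccc1-n1cnnn1)[C@@H]1[C@H]2C[C@H]2CN1C(=O)[C@H](O)CC1CC1`, gives 3.4 10^-6 cm/s. Compound 2, `O=C(NCc1cc(Cl)ccc1-n1cnnn1)[C@@H]1CC=NN1C(=O)[C@H](O)C1CCCCC1`, gives 19 10^-6 cm/s, and compound 3, `O=C(NCc1cc(Cl)ccc1-n1cnnn1)[C@@H]1C[C@@H]2C[C@@H]2N1C(=O)[C@H](O)Cn1cccn1`, gives 0.45 10^-6 cm/s. Compound 1 therefore stands second of the three: compound 2 lies higher and compound 3 lower, both gaps beyond the scatter. Compound 4, `O=C(NCc1cc(Cl)ccc1-n1cnnn1)[C@@H]1[C@H]2C[C@H]2CN1C(=O)[C@H](O)C1CCCCC1`, keeps the core of compound 1 and differs from it in one place: cyclohexyl in place of cyclopropylmethyl on a saturated chain carbon bound to a carbonyl carbon and an oxygen on a saturated carbon. Within the data shown here, no step between measured compounds that share this change is available, so the expectation rests on the values themselves. Compound 4 is expected to give a higher number in this assay, a step of a 2.4-fold higher number from compound 1 to compound 4 (0.37 log units; beyond the scatter), because compound 2 with its cyclohexyl gives 19 10^-6 cm/s. The estimate for compound 4 is 8 10^-6 cm/s, in a range from 3.5 10^-6 cm/s to 18 10^-6 cm/s.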

Compound 4, apparent permeability: 25 10^-6 cm/s
Beside the measured number, compound 4's estimate is 3.1-fold (0.49 log units) below it; the measured number lies above the stated range.
By their numbers in this assay, from the lowest: compound 3; then compound 1; then compounds 2 and 4 (each within the scatter of the next).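

In this assay, among these compounds, cyclohexyl in place of cyclopropylmethyl gives a 7.4-fold higher number from compound 1 to compound 4 (0.87 log units; beyond the scatter), the only step here in which the rest of the molecule stays fixed. It shows that a change at this position alone, on the core of compound 1, can move the number beyond the usual scatter. Nothing measured here explains this rise. Still open, from the compounds shown here alone, is how an amine, a carboxylic acid or a longer chain at this position would compare with cyclohexyl. Also open, going by these compounds, is whether the same change on another core gives a step of similar size.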